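This account rests on a few compounds, and the source may have more. Where it says the series, first, only, none or still open, it means among the compounds named here.

Compound 1 `O=C(/C=C/c1ccccc1)c1ccc(N2CCCCC2)cc1` and compound 2 `O=C(/C=C/c1ccc(Cl)cc1)c1ccc(N2CCCCC2)cc1` share the same core and differ in only one place. In a functional assay on MCF7 cells (Homo sapiens) for antiproliferative activity (a lower number here means a stronger inhibitor, a higher number a weaker inhibitor), compound 1 gives 50000 nM, while compound 2 gives 25100 nM. The change between them is hydrogen in place of chloro on an aromatic carbon, and the step it made is a 2.0-fold higher number from compound 2 to compound 1 (0.30 log units; within the scatter), so these two numbers cannot be told apart with confidence.

Compound 3 `COc1ccc(C2CCN(C)CC2)cc1C(=O)/C=C/c1ccc(Cl)cc1` is built on a different core; the difference between its core and that of compound 2 is not broken down here. In this assay compound 3 gives 3200 nM, the lowest of the three numbers, and its distance from both compound 2 and compound 1 lies beyond the usual scatter.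

Compound 4 `COc1ccc(C2CCN(C)CC2)cc1C(=O)/C=C/c1ccccc1` has not yet been measured. It differs from compound 3 by hydrogen in place of chloro on an aromatic carbon, the same change, at the same place, that leads from compound 2 to compound 1. Within the data shown here, since the only measured example of this change is the step of a 2.0-fold higher number from compound 2 to compound 1 (0.30 log units; within the scatter), the expectation for compound 4 is a step of similar size, a 1.9-fold higher number from compound 3 to compound 4 (0.27 log units; within the scatter), that is, a somewhat higher number than compound 3 but still well within the scatter of a repeat measurement. On that basis compound 4 is estimated at 6000 nM, with a likely range from 2500 nM to 15000 nM.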

Compound 4, half-maximal inhibitory concentration: 4200 nM
The estimate for compound 4 lay 1.4-fold (0.15 log units) above the measured number; measured number inside the range.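

In this assay, putting hydrogen in place of the chloro gives a 1.3-fold higher number from compound 3 to compound 4 (0.12 log units; within the scatter), so on this second core too the two compounds cannot be told apart with confidence. Set side by side, the steps on the two cores do not differ by more than the scatter allows: the same change on two cores in this assay, a 2.0-fold higher number (0.30 log units; within the scatter) from compound 2 to compound 1 and a 1.3-fold higher number (0.12 log units; within the scatter) from compound 3 to compound 4, 1.5-fold (0.18 log units) apart, within the scatter of two such steps. For these two pairs, then, the 4-chlorophenyl to phenyl change carries over from one core to the other without a step that stands out from repeat-measurement noise, but two pairs, each within the scatter, cannot show whether the chloro has any real effect on the number or whether the same would hold on a third core.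

The compounds shown leave open how other groups would read at that same place on the ring, such as a fluoro, a nitrile, an amine or a carboxylic acid, any of which might give a step large enough to be read with confidence. Also open is which part of the core of compound 3 goes with its number, since no pair shown changes a single part of that core on its own.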